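The source may hold more compounds than are shown below. What is called first, only, known or untested is meant among the compounds shown, and "the series" means these compounds.

Measured in a functional assay on HL-60 cells (Homo sapiens) for cytotoxicity, read by WST assay, with a stated time of 48 h; on this read-out lower numbers stand for an effect already at smaller amounts and higher numbers for an effect only at larger amounts of compound:
Compound 1 `O=C1OC[C@H](Cc2ccccc2)[C@H]1Cc1ccccc1`: 77000 nM
Compound 2 `O=C1OC[C@H](Cc2ccccc2)[C@H]1Cc1ccccc1C(F)(F)F`: 37000 nM
Compound 3 `COCOc1cccc(C[C@H]2C(=O)OC[C@@H]2Cc2ccccc2)c1`: 80000 nM

Compound 1, at 77000 nM, stands level with compound 3 and above compound 2. The next compound, compound 4 `CCCCOc1ccc(C[C@H]2C(=O)OC[C@@H]2Cc2ccccc2)cc1`, keeps the core of compound 1 and changes one place: butoxy in place of hydrogen on an aromatic carbon. In words, this is butoxy in place of hydrogen on an aromatic carbon, para to a large group.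

Going by the values given here, two measured steps bear on this, since each also replaces a hydrogen on an aromatic carbon. With trifluoromethyl, the result was a 2.1-fold lower number from compound 1 to compound 2 (0.32 log units; beyond the scatter), a modest change. With methoxymethoxy, the result was a 1.0-fold higher number from compound 1 to compound 3 (0.02 log units; within the scatter), so no real change. Methoxymethoxy is the closer comparison, as it is also an oxygen-linked chain, but butoxy itself has not been tested on this core. A small step is therefore expected in this assay, most likely within the scatter and, if anything, towards a lower number.

The expected change is a 1.5-fold lower number from compound 1 to compound 4 (0.19 log units; within the scatter). For compound 4, the estimated value is 50000 nM, with an expected range from 20000 nM to 100000 nM.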

Compound 4, half-maximal effective concentration: 23000 nM
Beside the measured number, compound 4's estimate is 2.2-fold (0.34 log units) above it; low and high end bracket the measured number.
By their numbers in this assay, from the lowest: compounds 4 and 2 (each within the scatter of the next); then compounds 1 and 3 (each within the scatter of the next).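

In this assay, butoxy on an aromatic carbon, para to a large group, gives a 3.3-fold lower number from compound 1 to compound 4 (0.52 log units; beyond the scatter) and so shows that an oxygen-linked chain on this ring can shift the number beyond the scatter. Methoxymethoxy gave a 1.0-fold higher number from compound 1 to compound 3 (0.02 log units; within the scatter) and did not show this. Nothing at hand explains why one chain shifts the number and the other does not.

The compounds shown leave open whether the step depends on chain length, as neither a shorter methoxy nor a longer hexyloxy appears among them at this place. They also leave open whether a different kind of group there, such as an amine or a carboxylic acid, would give a similar step.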